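Notes on the series: vinyl in place of thiophen-3-yl

The source may hold more compounds than are shown below. What is called first, only, known or untested is meant among the compounds shown, and "the series" means these compounds.

Measured so far:
compound 1 `O=C(Nc1ccc(F)cc1F)c1cc(=O)[nH]c2cc(Br)ccc12` — > 20000 nM
compound 2 `O=C(Nc1ccccn1)c1cc(=O)[nH]c2cc(Br)ccc12` — 9800 nM
compound 3 `O=C(Nc1cccc(F)c1)c1cc(=O)[nH]c2cc(-c3ccsc3)ccc12` — 4300 nM

All three were tested in a functional assay on KYSE-410 cells (Homo sapiens) for antiproliferative activity, read by MTT assay, with a stated time of 72 h; on this read-out higher numbers stand for weaker inhibition and lower numbers for stronger inhibition. The value of compound 1 is a limit of this assay, not a number (the limit of > 20000 nM in this assay, at which 1 of the 3 values shown sits). Among the two numbers shown, compound 3 stands lowest; the nearest, that of compound 2, lies beyond the usual scatter above it.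

Next comes compound 4 `C=Cc1ccc2c(C(=O)Nc3cccc(F)c3)cc(=O)[nH]c2c1`, which differs from compound 3 by vinyl in place of thiophen-3-yl on an aromatic carbon. Among the compounds with values here, no measured pair shows a change of this kind, so the expectation rests on the structural change alone. The step of a 1.9-fold higher number from compound 3 to compound 4 (0.27 log units; within the scatter) is expected to go toward weaker inhibition, beyond the scatter. Compound 4 is estimated at 8000 nM, with a range from 3000 nM to 25000 nM.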

Compound 4, half-maximal inhibitory concentration: 13600 nM
The estimate for compound 4 lay 1.7-fold (0.23 log units) below the measured number; low and high end bracket the measured number.
By their numbers in this assay, from the lowest: compound 3; then compounds 2 and 4 (each within the scatter of the next). At a limit, above all of these: compound 1.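

In this assay, vinyl in place of thiophen-3-yl gives a 3.2-fold higher number from compound 3 to compound 4 (0.50 log units; beyond the scatter), the first step read at this position in the series. The position therefore responds to the group it carries, and of these two groups, thiophen-3-yl gives the lower number. The step is modest, and nothing measured here accounts for it.

Still open, as far as these compounds go, is how an amine or a carboxylic acid would fare on this aromatic carbon. Also open, from the compounds shown here alone, is whether the step holds with the amide groups of compound 1 and compound 2.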